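A Second Fluoro on the Ring of Compound 1

A few compounds are considered here, and "the series" means these few. Any claim that something is new, unique, unknown or untested is made for them only; others in the source may bear on it.

Compound 1 `Cc1nc(C#Cc2cccc(F)c2)cs1`: 23 nM
Compound 2 `Cc1nc(C#Cc2cccc(C(F)(F)F)c2)cs1`: 413 nM
Compound 3 `Cc1nc(C#Cc2cccc(C#N)c2)cs1`: 0.94 nM

Of the compounds shown here, three built on one shared core have been tested in a functional assay on CHO cells for agonist activity at metabotropic glutamate receptor 5 (Homo sapiens), read by inositol phosphate accumulation; a lower number here means a stronger inhibitor, a higher number a weaker inhibitor. Compound 1 gives 23 nM, which is the second highest of the three numbers. The nearest neighbour is compound 2 with 413 nM, and the furthest is compound 3 with 0.94 nM. The two steps away from compound 1 both exchange the fluoro itself: an 18-fold higher number from compound 1 to compound 2 (1.25 log units; beyond the scatter), and a 24-fold lower number from compound 1 to compound 3 (1.39 log units; beyond the scatter); between those two, a 440-fold lower number from compound 2 to compound 3 (2.64 log units; beyond the scatter).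

Compound 4 `Cc1nc(C#Cc2cc(F)cc(F)c2)cs1` keeps the fluoro of compound 1 and adds a second one: fluoro in place of hydrogen on an aromatic carbon, meta to a fluoro group and meta to a group of 8 heavy atoms. Within the data shown here, none of the measured steps adds a group to an otherwise bare position; each replaces the one fluoro with a different group, so they show that this ring is sensitive to what sits on it but give no direct guide for a second fluoro. With the first fluoro retained, the expectation is a small change in this assay, most likely within the scatter, with a slight lean to a higher number.

Compound 4 is therefore estimated at 35 nM, expected between 8 nM and 150 nM, a step of a 1.5-fold higher number from compound 1 to compound 4 (0.18 log units; within the scatter).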

Compound 4, half-maximal inhibitory concentration: 25.3 nM
Compound 4: the middle estimate sits 1.4-fold (0.14 log units) above what was measured; low and high end bracket the measured number.
By their numbers in this assay, from the lowest: compound 3; then compounds 1 and 4 (each within the scatter of the next); then compound 2.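

In this assay, fluoro in place of hydrogen on an aromatic carbon, meta to a fluoro group and meta to a group of 8 heavy atoms, gives a step that cannot be told apart from repeat-measurement noise (a 1.1-fold higher number from compound 1 to compound 4 (0.04 log units; within the scatter)). Among these compounds, the earlier steps each swapped the one fluoro for another group and all landed beyond the scatter, whereas this is the first case where that fluoro stays and a bare ring position is filled, and here the added fluoro leaves the two compounds level. So, for this one pair, the ring that responded so strongly to exchanging its fluoro accepts a second fluoro at this position, though nothing available explains this result.

On these data alone, it remains open whether this position would accept anything other than fluoro, such as a chloro atom, a methoxy group or an amine, with the first fluoro kept. Also open, as far as these compounds go, is whether a second fluoro would behave the same way on compound 3 (0.94 nM), where a nitrile stands in place of the first fluoro.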